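Triazole aryl variation in the spiro series: compound 3

This account rests on a few compounds, and the source may have more. Where it says the series, first, only, none or still open, it means among the compounds named here.

The compounds share one core. Compound 1 `N#CC1=C(N)Oc2c(N)cc3nc4ccccc4nc3c2C12C(=O)N(Cc1cnnn1-c1cc(Cl)ccc1Cl)c1ccccc12` carries a 2,5-dichlorophenyl on the aromatic nitrogen of the triazole, and compound 2 `N#CC1=C(N)Oc2c(N)cc3nc4ccccc4nc3c2C12C(=O)N(Cc1cnnn1-c1ccc(F)c(Cl)c1)c1ccccc12` a 3-chloro-4-fluorophenyl at the same place. In a functional assay on HepG2 cells (Homo sapiens) for antiproliferative activity, read by MTT assay, with a stated time of 48 h (on this read-out higher numbers stand for weaker inhibition and lower numbers for stronger inhibition), compound 1 gives 33100 nM. For compound 2 this assay returns only a limit, > 50000 nM, and no number. Compound 2 thus stands at the weaker end of the two values shown, at the position described by the limit of > 50000 nM in this assay, at which 1 of the 2 values shown sits. Going by these compounds, the step of an at least 1.5-fold higher number from compound 1 to compound 2 (0.17 log units; that floor lies within the scatter) is accordingly only a floor, and its true size is unknown.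

Compound 3 `N#CC1=C(N)Oc2c(N)cc3nc4ccccc4nc3c2C12C(=O)N(Cc1cnnn1-c1ccc(Cl)cc1[N+](=O)[O-])c1ccccc12` is the next variation: 4-chloro-2-nitrophenyl in place of 3-chloro-4-fluorophenyl on an aromatic nitrogen. Within the data shown here, no measured step covers a nitro group at this place or this arrangement of the chloro. Among the measured compounds shown here, the one step that bears on the change, from compound 1 to compound 2, shows that exchanging the halogens on this aryl moved the read-out into the limit. Both values shown are weak, so compound 3 is expected to stay weak, with a real chance that this assay again reports only a limit. Compound 3 is estimated at 45000 nM, within 18000 nM to 120000 nM. This estimate means an expected step of an at least 1.1-fold lower number from compound 2 to compound 3 (0.04 log units; that floor lies within the scatter), not beyond the scatter.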

Compound 3, half-maximal inhibitory concentration: > 50000 nM
Compound 3: a limit, no number; the forecaster's own chance of this, stated with the estimate: 55%; at least 1.1-fold (0.04 log units) between middle value and limit.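

In this assay, among these compounds, the 4-chloro-2-nitrophenyl group gives compound 3 only a limit and no number, so the first nitro group at this place yields no readable value, and the step between compound 2 and compound 3 cannot be read. Among the compounds shown here, the one readable step for the new compound is an at least 1.5-fold higher number from compound 1 to compound 3 (0.17 log units; that floor lies within the scatter), and as a floor it leaves the true size unknown. Of the three aryl groups on this aromatic nitrogen, only the 2,5-dichlorophenyl of compound 1 keeps a number, while two differently substituted rings now end at the same point: the limit of > 50000 nM in this assay, at which 2 of the 3 values shown sit.

Still open, going by these compounds, is how far compound 2 and compound 3 really lie from compound 1, since neither has a number to set against it. Also open, on these data alone, is whether this place can give stronger inhibition at all, which an unsubstituted phenyl, a phenyl bearing an amine or a carboxylic acid, or a saturated ring such as cyclohexyl on the same nitrogen would help to settle.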